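The source may hold more compounds than are shown below. What is called first, only, known or untested is meant among the compounds shown, and "the series" means these compounds.

Compound 1 `CS(=O)(=O)c1cccc(S(=O)(=O)N(C2CC2)C2CCN(C(=O)c3cc(F)ccc3S(C)(=O)=O)CC2)c1` shows no measurable effect in an assay on HEK293 cells for inhibition of Voltage-dependent N-type calcium channel subunit alpha-1B (Homo sapiens), read by FLIPR and calcium flux, tested at 1 uM (on this read-out higher numbers stand for more inhibition at the one concentration tested (going by the name of the read-out) and lower numbers for less inhibition), where compound 1 gives 0%. Compound 2 `CS(=O)(=O)c1ccc(F)cc1C(=O)N1CCC(N(C2CC2)S(=O)(=O)c2ccccc2C(F)(F)F)CC1` carries 2-(trifluoromethyl)phenyl in place of 3-(methylsulfonyl)phenyl on a sulfonyl sulfur, and in this assay compound 2 gives 17%. That swap produced a number 17 percentage points higher from compound 1 to compound 2 (beyond the scatter). Going by the values given here, of the two measured numbers, compound 2 stands highest, its only neighbour being compound 1, whose number is lower beyond the scatter; even so, both readings are small inhibitions at the single concentration tested. Compound 3 `CS(=O)(=O)c1ccc(F)cc1C(=O)N1CCC(N(C2CC2)S(=O)(=O)c2ccc(OC(F)(F)F)cc2)CC1` alters the same group once more: 4-(trifluoromethoxy)phenyl in place of 2-(trifluoromethyl)phenyl on a sulfonyl sulfur. Among the compounds with values here, only one measured step bears on this, the one from compound 1 to compound 2, which exchanged the aryl group on the same sulfonyl sulfur and moved the read-out only modestly. Exchanging one aryl group for another at this place is therefore expected to give only a small step in this assay, a number 2 percentage points lower from compound 2 to compound 3 (within the scatter), most likely none beyond the scatter. Compound 3 is expected to give 15% in this assay, with a likely range from 0% to 40%.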

Compound 3, a percentage reported as inhibition, at one concentration (the size of the read-out at that concentration, not a potency): 0%
Compound 3: the middle estimate sits 15 percentage points above what was measured, within the range that was stated.
By their numbers in this assay, from the lowest: compounds 1 and 3 (each within the scatter of the next); then compound 2.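

In this assay, changing the aryl group on this sulfonyl sulfur can matter: 4-(trifluoromethoxy)phenyl in place of 2-(trifluoromethyl)phenyl gives a number 17 percentage points lower from compound 2 to compound 3 (beyond the scatter), so the small inhibition seen earlier is lost. Set against 3-(methylsulfonyl)phenyl, the same group gives no change at the digits printed from compound 1 to compound 3 (within the scatter), so of the three aryl groups shown at this place, only 2-(trifluoromethyl)phenyl stands apart, and the other two read alike despite carrying different groups. Nothing measured here gives a reason for this difference.

From the compounds shown here alone, the step from compound 2 to compound 3 changes both the group on the ring and the number in its name, so it remains open which of the two changes matters; 4-(trifluoromethyl)phenyl and 2-(trifluoromethoxy)phenyl at the same sulfonyl sulfur would tell them apart. Going by these compounds, it is also open whether a plain phenyl or a 2-chlorophenyl group would read like compound 2 or like compound 3, and so whether the reading of compound 2 depends on trifluoromethyl itself.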